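The source may report more compounds than this note shows. Statements on the series, on what has been measured and on what is new or still open speak of the compounds shown alone.

In a functional assay on HCT-116 cells (Homo sapiens) for cytotoxicity, read by MTT assay, with a stated time of 72 h (a lower number here means a stronger inhibitor, a higher number a weaker inhibitor), compound 1 `Nc1ccccc1NC(=O)c1ccc(NC(=S)NCc2cccnc2)cc1` gives 1000 nM and compound 2 `Nc1ccccc1NC(=O)c1ccc(NC(=S)NCc2cncc(F)c2)cc1` gives 15000 nM. Within the data shown here, compound 2 thus holds the higher of the two numbers, and the only measured step is large: a 15-fold higher number from compound 1 to compound 2 (1.18 log units; beyond the scatter), with fluoro in place of hydrogen on an aromatic carbon. Compound 3 `Nc1ccccc1NC(=O)c1ccc(NC(=S)NCc2cccc(Cl)c2)cc1` keeps the shared core and differs from compound 2 in one group: 3-chlorophenyl in place of 5-fluoropyridin-3-yl on a saturated chain carbon bound to an amide-type nitrogen. Here 3-chlorophenyl stands in place of 5-fluoropyridin-3-yl on a saturated chain carbon bound to an amide-type nitrogen. The measured step bears on this only in part. Among the measured compounds shown here, compound 3 loses the fluoro group, whose arrival came with a 15-fold higher number from compound 1 to compound 2 (1.18 log units; beyond the scatter), but it brings a chloro group of its own, and no measured step covers the exchange of a ring with a hetero atom for a ring of carbon only. A moderate move back towards compound 1 is therefore expected, though with wide uncertainty. The expected change is a 5.0-fold lower number from compound 2 to compound 3 (0.70 log units; beyond the scatter). Compound 3 is estimated to read about 3000 nM, with an expected range from 700 nM to 12000 nM.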

Compound 3, half-maximal inhibitory concentration: 5900 nM
Compound 3: the middle estimate sits 2.0-fold (0.29 log units) below what was measured; measured number inside the range.
By their numbers in this assay, from the lowest: compound 1; then compound 3; then compound 2.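

In this assay, a ring of carbon only is tolerated on the saturated chain carbon bound to an amide-type nitrogen: 3-chlorophenyl in place of 5-fluoropyridin-3-yl brings a 2.5-fold lower number from compound 2 to compound 3 (0.41 log units; beyond the scatter) and so recovers part of the ground lost with the fluoro group. The same group set against pyridin-3-yl gives a 5.9-fold higher number from compound 1 to compound 3 (0.77 log units; beyond the scatter) and shows that, among these three rings, the one with no substituent keeps the lowest number, while both rings that carry a halogen read higher, whether or not the ring holds a hetero atom. Nothing at hand explains this order of the three rings.

Each step exchanges the ring and its substituent together, so the share of the ring nitrogen and the share of the chloro group in these numbers cannot be told apart. A plain phenyl ring would separate the two, and a methoxy group or an amine on the ring would show whether the rise in the number extends beyond the halogens.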